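Hydrazide to alanine amide on a trifluoromethyl pyrazolopyridine

This account rests on a few compounds, and the source may have more. Where it says the series, first, only, none or still open, it means among the compounds named here.

Measured in a functional assay on DU-145 cells (Homo sapiens) for cytotoxicity, read by MTT assay, with a stated time of 24 h; a lower number here means a stronger inhibitor, a higher number a weaker inhibitor:
- compound 1 `NNC(=O)Cn1nc(N)c2c(C(F)(F)F)cc(-c3ccccc3)nc21`: 52400 nM
- compound 2 `Nc1nn(CC(=O)N2CCOCC2)c2nc(-c3ccccc3)cc(C(F)(F)F)c12`: 5100 nM
- compound 3 `Nc1nn(CC(=O)N2CCCCC2)c2nc(-c3ccccc3)cc(C(F)(F)F)c12`: 3200 nM

Compound 1 has the highest number of the three, and its steps to the other two are large: a 10-fold lower number from compound 1 to compound 2 (1.01 log units; beyond the scatter) and a 16-fold lower number from compound 1 to compound 3 (1.21 log units; beyond the scatter). Between the two cyclic amides the gap is small, a 1.6-fold lower number from compound 2 to compound 3 (0.20 log units; within the scatter). Compound 4 `CC(NC(=O)Cn1nc(N)c2c(C(F)(F)F)cc(-c3ccccc3)nc21)C(=O)O` differs from compound 1 by 1-carboxyethyl in place of amino on an amide-type nitrogen. The measured steps change the carbonyl substituent rather than the amide-type nitrogen, so they bear only loosely on this change; both show that altering the aminoamino end of compound 1 lowered the number. A moderate drop is therefore expected, a 2.1-fold lower number from compound 1 to compound 4 (0.32 log units; beyond the scatter), and compound 4 is estimated at 25000 nM, ranging from 6000 nM to 80000 nM.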

Compound 4, half-maximal inhibitory concentration: 22400 nM
For compound 4 the middle estimate is 1.1-fold (0.05 log units) above the measured one; the range from low to high includes it.
By their numbers in this assay, from the lowest: compounds 3 and 2 (each within the scatter of the next); then compound 4; then compound 1.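

In this assay, 1-carboxyethyl on the amide-type nitrogen gives a 2.3-fold lower number from compound 1 to compound 4 (0.37 log units; beyond the scatter), so this nitrogen accepts an open-chain substituent in place of amino with a modest gain. That gain stays short of the cyclic amides, with a 7.0-fold higher number from compound 3 to compound 4 (0.85 log units; beyond the scatter) and a 4.4-fold higher number from compound 2 to compound 4 (0.64 log units; beyond the scatter). No measurement shown here explains these steps. From the compounds shown here alone, it remains open whether the carboxylic acid of the 1-carboxyethyl group matters to the step, or whether its methyl ester or a plain ethyl group on the same nitrogen would give a similar number.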